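A hydroxy group enters on one aromatic carbon

A few compounds are considered here, and "the series" means these few. Any claim that something is new, unique, unknown or untested is made for them only; others in the source may bear on it.

Compound 1 `COc1ccc(Nc2c(-c3ccc(OC)cc3)nc3ccccn23)cc1`: 54000 nM
Compound 2 `COc1ccc(Nc2c(-c3cccc(B(O)O)c3)nc3ccccn23)cc1`: 58000 nM

Both values come from an ADME assay on Vero cells (Chlorocebus sabaeus) for cytotoxicity, read by MTT assay; on this read-out lower numbers stand for higher toxicity in this test and higher numbers for lower toxicity in this test. For the measured compounds named here, there, compound 2, at 58000 nM, lies within the scatter of compound 1, the only other compound measured, so it holds no separate place on these numbers. The next compound is compound 3 `COc1ccc(Nc2c(-c3cccc(O)c3)nc3ccccn23)cc1`, which keeps the rest of compound 2 and differs in one group: one oxygen atom in place of a group of 3 heavy atoms (1 boron, 2 oxygen; no ring), on an aromatic carbon. Going by the values given here, only one measured step bears on this change: a 1.1-fold higher number from compound 1 to compound 2 (0.03 log units; within the scatter). It swapped a larger group on an aromatic carbon and stayed within the scatter. Among the compounds with values here, no measured compound carries the hydroxy group, so this evidence is thin, and no direction can be argued from it. The expected change is a 1.2-fold lower number from compound 2 to compound 3 (0.06 log units; within the scatter), which would not go beyond the scatter. For compound 3 the estimated value is 50000 nM, with an expected range of 20000 nM to 120000 nM.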

Compound 3, concentration lethal to 50% of the cells: 74000 nM
Estimate against measurement, compound 3: 1.5-fold (0.17 log units) below; measured number inside the range.
By their numbers in this assay, from the lowest: compounds 1, 2 and 3 (each within the scatter of the next).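

In this assay, the hydroxy group in place of the boron-bearing group gives a 1.3-fold higher number from compound 2 to compound 3 (0.11 log units; within the scatter), so at this aromatic carbon the exchange does not carry the read-out beyond the scatter. The exchange of the whole aryl group, 3-hydroxyphenyl in place of 4-methoxyphenyl, gives a 1.4-fold higher number from compound 1 to compound 3 (0.14 log units; within the scatter), and the three compounds therefore hold no separate places on these numbers. Nothing measured here accounts for how little the number differs across these groups.

From the compounds shown here alone, whether an amine or a carboxylic acid on this aromatic carbon would give a number beyond the scatter stays open. So does whether a change elsewhere on the shared core would move the read-out in this assay at all.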